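The source may hold more compounds than are shown below. What is called first, only, known or untested is meant among the compounds shown, and "the series" means these compounds.

Measured in a functional assay on L1210 cells (Mus musculus) for cytotoxicity, read by MTT assay; a lower number here means a stronger inhibitor, a higher number a weaker inhibitor:
- Compound 1 `O=C(N/N=C/c1ccc(F)cc1)c1cn(C2CC2)c2cc(N3CCNCC3)c(F)cc2c1=O`: 25000 nM
- Compound 2 `O=C(N/N=C/c1ccccc1)c1cn(C2CC2)c2cc(N3CCNCC3)c(F)cc2c1=O`: 25000 nM
- Compound 3 `COc1cc(/C=N/NC(=O)c2cn(C3CC3)c3cc(N4CCNCC4)c(F)cc3c2=O)cc(OC)c1OC`: 25000 nM

Compound 1 and compound 2 stand level with compound 3 at 25000 nM. Compound 4 `O=C(N/N=C/c1ccccc1O)c1cn(C2CC2)c2cc(N3CCNCC3)c(F)cc2c1=O` differs from compound 3 by one change: 2-hydroxyphenyl in place of 3,4,5-trimethoxyphenyl on a carbon with a double bond to nitrogen. All three measured steps bear on it: no change at the digits printed from compound 1 to compound 2 (within the scatter), no change at the digits printed from compound 1 to compound 3 (within the scatter) and no change at the digits printed from compound 2 to compound 3 (within the scatter). Each of them is flat, including the two that exchange the group on the carbon with a double bond to nitrogen. However, none of the measured compounds carries the 2-hydroxyphenyl group, so the range is kept wide. In this assay, the expected result is a 1.1-fold lower number from compound 3 to compound 4 (0.06 log units; within the scatter), with no change beyond the scatter. For compound 4 the estimate is 22000 nM, with an expected range of 8000 nM to 32000 nM.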

Compound 4, half-maximal inhibitory concentration: 25000 nM
Estimate against measurement, compound 4: 1.1-fold (0.06 log units) below; the measured number falls inside the stated range.
By their numbers in this assay, from the lowest: compounds 1, 2, 3 and 4 (each within the scatter of the next).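

In this assay, the 2-hydroxyphenyl group is the only group shown on the carbon with a double bond to nitrogen that carries a hydrogen-bond donor, yet the readings show no change at the digits printed from compound 3 to compound 4 (within the scatter), no change at the digits printed from compound 2 to compound 4 (within the scatter) and no change at the digits printed from compound 1 to compound 4 (within the scatter). The flat result at this position therefore now extends to a hydroxy-bearing phenyl as well as to the phenyl, 4-fluorophenyl and 3,4,5-trimethoxyphenyl groups. Nothing available explains this result. The compounds shown leave open whether an amine or a carboxylic acid on this phenyl ring would shift the number. From the compounds shown here alone, a longer chain in place of the ring also remains open.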